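Ester-bearing chains on the shared core

A few compounds are considered here, and "the series" means these few. Any claim that something is new, unique, unknown or untested is made for them only; others in the source may bear on it.

Measured compounds:
compound 1, `CCCCCCOc1ccc2c(=O)cc(-c3cc(C(C)(C)C)c(O)c(C(C)(C)C)c3)oc2c1`, 5000 nM
compound 2, `CC(C)(C)c1cc(-c2cc(=O)c3ccc(OCCO)cc3o2)cc(C(C)(C)C)c1O`, 3000 nM
compound 3, `CCCCCOC(=O)COc1ccc2c(=O)cc(-c3cc(C(C)(C)C)c(O)c(C(C)(C)C)c3)oc2c1`, 5000 nM

All three carry the same core and differ only in the chain on the aromatic oxygen. In a functional assay for inhibition (on this read-out lower numbers stand for stronger inhibition and higher numbers for weaker inhibition), compound 3 gives 5000 nM, level with compound 1 at the digits printed; together they are the highest numbers of the three, and compound 2 sits nearest below, although every gap between them falls within the scatter: a 1.7-fold lower number from compound 1 to compound 2 (0.22 log units; within the scatter), no change at the digits printed from compound 1 to compound 3 (within the scatter), a 1.7-fold higher number from compound 2 to compound 3 (0.22 log units; within the scatter).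

Compound 4, `CCOC(=O)C(C)(C)Oc1ccc2c(=O)cc(-c3cc(C(C)(C)C)c(O)c(C(C)(C)C)c3)oc2c1`, has not yet been measured. Relative to compound 3 the change is 1-(ethoxycarbonyl)-1-methylethyl in place of (pentyloxycarbonyl)methyl on an oxygen on an aromatic ring. Both the ester and the chain on the aromatic oxygen are reshaped, so the most relevant comparisons are the steps that already altered this chain: no change at the digits printed from compound 1 to compound 3 (within the scatter) and a 1.7-fold higher number from compound 2 to compound 3 (0.22 log units; within the scatter). Neither moved the number beyond the scatter. A small change within the chain, keeping the ester, is therefore expected to leave this assay essentially unchanged: no change at the digits printed from compound 3 to compound 4 (within the scatter). Compound 4 is estimated at 5000 nM, expected between 2500 nM and 10000 nM.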

Compound 4, half-maximal inhibitory concentration: 3000 nM
Compound 4: the middle estimate sits 1.7-fold (0.22 log units) above what was measured; measured number inside the range.
By their numbers in this assay, from the lowest: compounds 2, 4, 1 and 3 (each within the scatter of the next).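

In this assay the new chain stays within the scatter of all three earlier chains on this oxygen, whether set against the longer unbranched ester (a 1.7-fold lower number from compound 3 to compound 4 (0.22 log units; within the scatter)), the 2-hydroxyethyl chain (no change at the digits printed from compound 2 to compound 4 (within the scatter)) or the hexyl chain (a 1.7-fold lower number from compound 1 to compound 4 (0.22 log units; within the scatter)). Compound 4 therefore extends the earlier picture of a flat read-out to a different ester chain, as 1-(ethoxycarbonyl)-1-methylethyl on an oxygen on an aromatic ring reads the same within the scatter as (pentyloxycarbonyl)methyl, and no chain shown so far separates from the others on this read-out. Nothing on hand accounts for this flat result or shows how these chains act in the assay.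

Compound 4 changes the ester alkyl group and the methyl substitution of the chain in a single step, so the pair leaves their separate contributions unresolved; (ethoxycarbonyl)methyl and 1-(pentyloxycarbonyl)-1-methylethyl would each isolate one of them. Also open, on these data alone, is whether any group on this oxygen moves the number beyond the scatter, for example a chain ending in a carboxylic acid or an amine.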